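Dropping the methoxy from the benzylamide side chain

The source may hold more compounds than are shown below. What is called first, only, known or untested is meant among the compounds shown, and "the series" means these compounds.

Three measured members share the core of compound 1 `COc1ccccc1CN(C)C(=O)CSc1c[nH]c2ccccc12`. In an ADME assay on HEK-293T cells (Homo sapiens) for cytotoxicity, read by CCK-8 assay, with a stated time of 24 h (a lower number here means that less compound is tolerated, a higher number that more compound is tolerated), compound 1 gives > 100000 nM, which is a limit of the assay and not a number. Compound 2 `COc1ccccc1CNC(=O)CSc1c[nH]c2cccc(Br)c12` gives > 100000 nM in this assay, again only a limit. Compound 3 `COc1ccccc1CNC(=O)CSc1c[nH]c2ccc(Br)cc12` gives > 100000 nM in this assay, once more a limit. Compound 1 therefore stands at no particular place on the numbers shown: all three values sit at the limit of > 100000 nM in this assay, at which 3 of the 3 values shown sit, and no measured value separates from any other.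

Compound 4 `CN(Cc1ccccc1)C(=O)CSc1c[nH]c2ccccc12` differs from compound 1 by hydrogen in place of methoxy on an aromatic carbon. Among the compounds with values here, no step between two measured compounds exists, so the size of the step to compound 4 can only be expected, not read off. Since each measured value sits at the limit of > 100000 nM in this assay, at which 3 of the 3 values shown sit, the expectation is a step of none beyond the scatter, with the assay most likely reporting a limit again.

The step from compound 1 to compound 4 is thus estimated as a number no higher from compound 1 to compound 4 (the limit leaves the size open) in this assay. Compound 4 is expected at 100000 nM in this assay. For compound 4 the estimated range runs from 50000 nM to 300000 nM.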

Compound 4, half-maximal cytotoxic concentration: > 100000 nM
Compound 4 ended at the assay's limit; the forecaster's own chance of this, stated with the estimate: 85%; the middle value sits exactly at the limit.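

No step can be read from compound 1 to compound 4 in this assay, since both results are limits and not numbers. The whole series stays at one limit: the limit of > 100000 nM in this assay, at which 4 of the 4 values shown sit.

The compounds shown leave open whether any change to the shared core would give a measurable value in this assay.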